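The source may hold more compounds than are shown below. What is called first, only, known or untested is meant among the compounds shown, and "the series" means these compounds.

Measured so far:
compound 1, `Cn1ccc2c(Oc3ccc(NC(=O)c4cn(-c5ccccc5)c5ccccc5c4=O)cc3F)ccnc21`: 2170 nM
compound 2, `O=C(Nc1ccc(Oc2ccnc3[nH]ccc23)c(F)c1)c1cn(-c2ccccc2)c2ccccc2c1=O`: 760 nM

Both compounds were tested in a functional assay on HepG2 cells (Homo sapiens) for inhibition, read by MTT assay, with a stated time of 72 h; a lower number here means a stronger inhibitor, a higher number a weaker inhibitor. Compound 2 gives the lowest of the two numbers; its nearest neighbour is compound 1, and the step of a 2.9-fold lower number from compound 1 to compound 2 (0.46 log units; beyond the scatter) comes from a hydrogen in place of a methyl on an aromatic nitrogen of the shared core.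

Compound 3, `O=C(Nc1ccc(Oc2ccnc3[nH]ccc23)c(F)c1)c1cn(-c2ccc(F)c(Cl)c2)c2ccccc2c1=O`, has not yet been measured. It differs from compound 2 in one place: 3-chloro-4-fluorophenyl in place of phenyl on an aromatic nitrogen. Within the data shown here, the only measured step concerns a different position, the aromatic nitrogen of the core, so no measured step bears on this change. With nothing to go on beyond the two numbers above, the expected step of a 1.3-fold lower number from compound 2 to compound 3 (0.10 log units; within the scatter) is taken as none beyond the scatter. Compound 3 is therefore estimated at 600 nM, with a range from 200 nM to 1800 nM.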

Compound 3, half-maximal inhibitory concentration: 3390 nM
Compound 3: middle estimate off by 5.7-fold (0.75 log units), on the low side; the whole stated range lies below it.
By their numbers in this assay, from the lowest: compound 2; then compounds 1 and 3 (each within the scatter of the next).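

The ring on the aromatic nitrogen is not a silent place in the molecule: putting 3-chloro-4-fluorophenyl in place of phenyl gives a 4.5-fold higher number from compound 2 to compound 3 (0.65 log units; beyond the scatter) in this assay, which means a weaker inhibitor. Among these compounds, the earlier pair varied only the aromatic nitrogen of the shared core, so this is the first measured sign that a change at this second nitrogen also moves the number. Here, adding the two halogens to the phenyl ring goes with a loss of activity, although one step cannot show a general pattern, and no measurement shown explains it.

Chlorine and fluorine enter together, so 3-chlorophenyl and 4-fluorophenyl would be needed to separate their contributions. Also open, from the compounds shown here alone, is how a pyridine ring or a simple methyl group would fare at this position.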